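Swapping an Amide for an Ester on the Shared Core

The source may hold more compounds than are shown below. What is called first, only, known or untested is meant among the compounds shown, and "the series" means these compounds.

Measured compounds:
compound 1, `CCOC(=O)CN(C)C(=O)c1ccc(C(CC)(CC)c2ccc(OCC(O)C(C)(C)C)c(C)c2)n1CC`: 210 nM
compound 2, `CCn1c(C(=O)N(C)c2ccccc2)ccc1C(CC)(CC)c1ccc(OCC(O)C(C)(C)C)c(C)c1`: 6400 nM

Going by the values given here, in an assay on HL-60 cells for agonist activity at vitamin D3 receptor (Homo sapiens), read by microscopy, with a stated time of 96 h (a lower number here means that less compound is needed, a higher number that more compound is needed for the effect), compound 2 has the higher of the two numbers; the only measured step leading to it is a 30-fold higher number from compound 1 to compound 2 (1.48 log units; beyond the scatter). Compound 3, `CCOC(=O)c1ccc(OC(=O)c2ccc(C(CC)(CC)c3ccc(OCC(O)C(C)(C)C)c(C)c3)n2CC)cc1`, differs from compound 2 by 4-(ethoxycarbonyl)phenoxy in place of methyl(phenyl)amino on a carbonyl carbon. That step is the only one that bears on this change, and it shows that an ethoxycarbonyl-bearing group gave the lower number, so a move back toward compound 1 is expected: a 7.1-fold lower number from compound 2 to compound 3 (0.85 log units; beyond the scatter). For compound 3 the expected value is 900 nM, with a range from 150 nM to 5000 nM.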

Compound 3, half-maximal effective concentration: > 50000 nM
Compound 3: only a limit was reported (the forecaster's own chance of this, stated with the estimate: 5%); middle value at least 55-fold (1.74 log units) away from the limit.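

Compound 3 gives only a limit of the assay, not a number, in this assay: the limit of > 50000 nM in this assay, at which 1 of the 3 values shown sits. Placing 4-(ethoxycarbonyl)phenoxy on the carbonyl carbon gives an at least 7.8-fold higher number from compound 2 to compound 3 (0.89 log units; beyond the scatter), and the comparison with the amide carrying an ethoxycarbonyl group gives an at least 230-fold higher number from compound 1 to compound 3 (2.37 log units; beyond the scatter). An ethoxycarbonyl group alone therefore does not secure a low number at this position, as compound 1 and compound 3 both carry one.

Compound 3 changes the linking atom and the ring together, so the compounds shown cannot separate these two changes. From the compounds shown here alone, how a plain phenoxy group or a carboxylic acid in place of the ethyl ester would read remains open.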